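This account rests on a few compounds, and the source may have more. Where it says the series, first, only, none or still open, it means among the compounds named here.

Measured so far in a functional assay on NCI-H460 cells (Homo sapiens) for cytotoxicity, read by MTT assay, with a stated time of 3 days; on this read-out higher numbers stand for weaker inhibition and lower numbers for stronger inhibition:
Compound 1 `N#Cc1c(Cl)nc(SCc2nc3ccccc3[nH]2)nc1-c1ccccc1` gives 3.28 nM
Compound 2 `CNc1nc(SCc2nc3ccccc3[nH]2)nc(-c2ccccc2)c1C#N` gives 3.2 nM
Compound 3 `N#Cc1c(Nc2nccs2)nc(SCc2nc3ccccc3[nH]2)nc1-c1ccccc1` gives 3.37 nM

These three share one core and differ only in the group on an aromatic carbon: chloro in compound 1, methylamino in compound 2 and (1,3-thiazol-2-yl)amino in compound 3. Compound 3 cannot be told apart from the other two, since a 1.0-fold higher number from compound 1 to compound 3 (0.01 log units; within the scatter) and a 1.1-fold higher number from compound 2 to compound 3 (0.02 log units; within the scatter) both lie within the scatter. The remaining pair is just as close, with a 1.0-fold lower number from compound 1 to compound 2 (0.01 log units; within the scatter) also within the scatter.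

Compound 4 `N#Cc1c(NC(N)=S)nc(SCc2nc3ccccc3[nH]2)nc1-c1ccccc1` keeps the shared core, and its change is a group of 3 heavy atoms (1 carbon, 1 nitrogen, 1 sulfur; no ring) in place of a group of 5 heavy atoms (3 carbon, 1 nitrogen, 1 sulfur; one five-membered aromatic ring with 2 hetero atoms), on a nitrogen on an aromatic ring on the same nitrogen. The 1,3-thiazol-2-yl group leaves, and a group with no ring enters.

The closest guide is a 1.1-fold higher number from compound 2 to compound 3 (0.02 log units; within the scatter), a swap on that same nitrogen that stayed within the scatter. The swaps from chloro were equally small, with a 1.0-fold lower number from compound 1 to compound 2 (0.01 log units; within the scatter) and a 1.0-fold higher number from compound 1 to compound 3 (0.01 log units; within the scatter) as the evidence. None of the three compounds carries the entering group, so this flat picture is only a thin guide.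

No shift beyond the scatter is expected, and the estimated change is a 1.0-fold lower number from compound 3 to compound 4 (0.01 log units; within the scatter) in this assay here.

Compound 4 is expected at 3.3 nM in this assay, with an estimated range from 1.9 nM to 6 nM here.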

Compound 4, half-maximal inhibitory concentration: 3.37 nM
Compound 4: middle estimate off by 1.0-fold (0.01 log units), on the low side; low and high end bracket the measured number.
By their numbers in this assay, from the lowest: compounds 2, 1, 3 and 4 (each within the scatter of the next).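

In this assay, removing the ring from this nitrogen leaves the number unchanged within the scatter: the ring-free group that replaces 1,3-thiazol-2-yl gives no change at the digits printed from compound 3 to compound 4 (within the scatter). The same group also stays within the scatter when it replaces the methyl on that nitrogen, with a 1.1-fold higher number from compound 2 to compound 4 (0.02 log units; within the scatter), and the whole substituent stays level with a single chlorine on the aromatic carbon, with a 1.0-fold higher number from compound 1 to compound 4 (0.01 log units; within the scatter). The flat picture therefore now spans a ring, a methyl, a ring-free group with a double bond and a lone chlorine at this place, though no measurement available here accounts for it.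

Since all four compounds lie within the scatter of one another, the compounds shown do not reveal whether any group at this place can move the number at all. A carboxylic acid, a longer alkyl chain or a plain amino group here might still shift it, and these four compounds give no way to predict the size or direction of such a shift.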